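Furan-2-yl in place of 1,3-thiazol-5-yl on a carbonyl carbon

This account rests on a few compounds, and the source may have more. Where it says the series, first, only, none or still open, it means among the compounds named here.

Measured in a functional assay on BXPC-3 cells (Homo sapiens) for antiproliferative activity, read by sulforhodamine B assay, with a stated time of 72 h; a lower number here means a stronger inhibitor, a higher number a weaker inhibitor:
- compound 1 `CC(C)(C)c1[nH]cnc1/C=c1\[nH]c(=O)/c(=C/c2cccc(C(=O)c3cccnc3)c2)[nH]c1=O`, 4.05 nM
- compound 2 `CC(C)(C)c1[nH]cnc1/C=c1\[nH]c(=O)/c(=C/c2cccc(C(=O)c3ccncc3)c2)[nH]c1=O`, 23.8 nM
- compound 3 `CC(C)(C)c1[nH]cnc1/C=c1\[nH]c(=O)/c(=C/c2cccc(C(=O)c3cncs3)c2)[nH]c1=O`, 17.1 nM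

Compound 3 lies within the scatter of compound 2, and the two show a 1.4-fold lower number from compound 2 to compound 3 (0.14 log units; within the scatter). Compound 1 holds the lowest number of the three, and the gap to compound 3 is beyond the scatter, with a 4.2-fold higher number from compound 1 to compound 3 (0.63 log units; beyond the scatter).

The change under consideration leads to compound 4 `CC(C)(C)c1[nH]cnc1/C=c1\[nH]c(=O)/c(=C/c2cccc(C(=O)c3ccco3)c2)[nH]c1=O`, with furan-2-yl in place of 1,3-thiazol-5-yl on a carbonyl carbon.

Within the data shown here, no measured step involves furan-2-yl. The closest evidence is the set of swaps at the same carbonyl carbon. Those are modest at most, as in a 5.9-fold higher number from compound 1 to compound 2 (0.77 log units; beyond the scatter), alongside the two steps above. Compound 3 and compound 4 both carry a five-membered aromatic ring there, so the data give no firm direction.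

The expected outcome is a 1.1-fold lower number from compound 3 to compound 4 (0.06 log units; within the scatter), a change not expected to exceed the scatter. For compound 4 the estimate in this assay is 15 nM, with an expected range of 5 nM to 45 nM.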

Compound 4, half-maximal inhibitory concentration in the BXPC-3 assay: 9.23 nM
For compound 4 the middle estimate is 1.6-fold (0.21 log units) above the measured one, within the range that was stated.
By their numbers in the BXPC-3 assay, from the lowest: compound 1; then compounds 4, 3 and 2 (each within the scatter of the next, the first and the last beyond it).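

In the BXPC-3 assay furan-2-yl on the carbonyl carbon stays level with 1,3-thiazol-5-yl, with a 1.9-fold lower number from compound 3 to compound 4 (0.27 log units; within the scatter), yet it separates from pyridin-4-yl, with a 2.6-fold lower number from compound 2 to compound 4 (0.41 log units; beyond the scatter). Pyridin-3-yl still keeps the lowest number in the BXPC-3 assay, with a 2.3-fold higher number from compound 1 to compound 4 (0.36 log units; beyond the scatter), so a five-membered aromatic ring with one hetero atom does not displace it. Among these compounds, the ring on this carbonyl carbon therefore need not carry nitrogen to stay in this range, although compound 1, the only compound ahead of compound 4, does carry it.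

In a physicochemical assay for solubility, read by HPLC, with a stated time of 24 h (on this read-out higher numbers stand for higher solubility and lower numbers for lower solubility), compound 3 gives < 0.1 ug/mL, which is a limit of the assay. In the physicochemical assay compound 4 gives < 0.1 ug/mL, which is also a limit of the assay. In the physicochemical assay the step from compound 3 to compound 4 cannot be read, as both sit at a limit of the assay: the limit of < 0.1 ug/mL in the physicochemical assay, at which 2 of the 2 values shown sit. On these data alone, whether a morpholine in place of the ring on the carbonyl carbon would clear that limit and hold the number in the BXPC-3 assay stays open.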